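Two Switches on a Diether Scaffold, and an Untested Partner

This account rests on a few compounds, and the source may have more. Where it says the series, first, only, none or still open, it means among the compounds named here.

Measured so far:
Compound 1 `COc1cc(CC(COCc2ccccc2)COCc2ccccc2)nc(OC)n1`: 3500 nM
Compound 2 `O=c1cc(CC(COCc2ccccc2)COCc2ccccc2)[nH]c(=O)[nH]1`: > 100000 nM (a limit)
Compound 3 `COc1cc(CC(O)COCc2ccccc2)nc(OC)n1`: > 100000 nM (a limit)

In a functional assay on HeLa cells (Homo sapiens) for antiproliferative activity, read by MTT assay, with a stated time of 72 h (a lower number here means a stronger inhibitor, a higher number a weaker inhibitor), compound 1 gives 3500 nM. For compound 2 the assay reports only a limit, > 100000 nM. For compound 3 the assay also reports only a limit, > 100000 nM. The two cores differ as follows: a group of 8 heavy atoms (4 carbon, 2 nitrogen, 2 oxygen; one six-membered aromatic ring with 2 hetero atoms) in place of a group of 10 heavy atoms (6 carbon, 2 nitrogen, 2 oxygen; one six-membered aromatic ring with 2 hetero atoms), on a saturated chain carbon, three bonds along the chain from two oxygens on a saturated carbon, and this produced an at least 28-fold higher number from compound 1 to compound 2 (1.45 log units; beyond the scatter). Compound 1 and compound 3 differ by hydroxy in place of (benzyloxy)methyl on a saturated chain carbon bound to two saturated chain carbons, which produced an at least 28-fold higher number from compound 1 to compound 3 (1.45 log units; beyond the scatter).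

Compound 4 `O=c1cc(CC(O)COCc2ccccc2)[nH]c(=O)[nH]1` has not been measured in this assay. It differs from compound 2 by hydroxy in place of (benzyloxy)methyl on a saturated chain carbon bound to two saturated chain carbons, the same change at the same place. Compound 2 already sits at the limit of > 100000 nM in this assay, at which 2 of the 3 values shown sit, so compound 4 is expected to remain at that limit as well, an expected step that the limit leaves unreadable from compound 2 to compound 4. The estimate for compound 4 is 300000 nM, within 100000 nM to 1000000 nM.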

Compound 4, half-maximal inhibitory concentration: > 100000 nM
Compound 4: a limit, no number; the forecaster's own chance of this, stated with the estimate: 90%; the middle value does not contradict the limit.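

Compound 2 and compound 4 both stand only at a limit, so no step between them can be read: the limit of > 100000 nM in this assay, at which 3 of the 4 values shown sit.

As far as these compounds go, whether hydroxy in place of (benzyloxy)methyl changes activity at all on the core of compound 2 stays open.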